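The compounds below may be only part of what the source reports. "The series", "measured", "known", "first", "only" and "open" are said of these compounds alone.

Measured in an ADME assay on microsomes from liver (Mus musculus, strain CD-1) for metabolic stability, read by LC-MS, tested at 2 uM; a lower number here means that the compound disappears faster, a higher number that the compound lasts longer:

- compound 1 `Cn1ccc2ccc(-c3cc(Nc4ccccc4S(N)(=O)=O)cc4nccnc34)cc21`: 0.5 h
- compound 2 `CN1CCC(NC(=O)c2ccncc2Nc2cc(-c3ccc4ccn(C)c4c3)c3nccnc3c2)CC1=O`: 0.717 h

Both compounds are short-lived in this assay on these numbers. Compound 2 gives 0.717 h and compound 1 gives 0.5 h, and these two values lie within the usual scatter of each other. Compound 2 therefore cannot be separated from compound 1 here, and it gives the only half-life measured for an amide of this kind.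

Compound 3 `CC(=O)N1CC(CNC(=O)c2ccncc2Nc2cc(-c3ccc4ccn(C)c4c3)c3nccnc3c2)C1` has not been measured yet. It carries (1-acetylazetidin-3-yl)methyl in place of 1-methyl-2-oxopiperidin-4-yl on an amide-type nitrogen. The two compounds have the same atoms, joined differently, and the rest of the structure is shared.

Among the measured compounds shown here, no measured pair shows what a swap of this kind does, so the data offer no direction for it. The best guide is the value of compound 2, 0.717 h, and the close agreement of compound 1 with it. The expected change is a 1.2-fold lower number from compound 2 to compound 3 (0.08 log units; within the scatter), a step that stays within the usual scatter.

For compound 3 the estimated half-life is 0.6 h, with an expected range from 0.3 h to 1.2 h.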

Compound 3, half-life: > 1 h
Compound 3 ended at the assay's limit; the forecaster's own chance of this, stated with the estimate: 5%; at least 1.6-fold (0.22 log units) between middle value and limit.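

In this assay, compound 3 gives > 1 h, which is a limit of the assay and not a number. Among the compounds shown here, this is the first reading of a change on the amide-type nitrogen: with the same atoms joined differently, (1-acetylazetidin-3-yl)methyl in place of 1-methyl-2-oxopiperidin-4-yl gives an at least 1.3-fold higher number from compound 2 to compound 3 (0.14 log units; that floor lies within the scatter), so this reshuffling of the side group does not shorten the half-life, and the position accepts a four-membered ring carrying an acetyl as well as a six-membered ring. Only a floor for the step can be read, so a gain beyond the usual scatter is possible but not shown, and the floor comes from this limit: the limit of > 1 h in this assay, at which 1 of the 3 values shown sits.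

The compounds shown leave open which part of the change matters: the four-membered ring, the acetyl on its nitrogen, or the methyl link that joins the ring to the amide-type nitrogen. A 1-acetylazetidin-3-yl group without that link, or an (azetidin-3-yl)methyl group with a free amine in place of the acetyl, would begin to pull these parts apart.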